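Swapping the halogenated phenyl on a fused triazolothiadiazine core

This account rests on a few compounds, and the source may have more. Where it says the series, first, only, none or still open, it means among the compounds named here.

Compound 1, `COc1ccc2cc(C(C)c3nnc4n3N=C(c3ccc(Br)cc3)CS4)ccc2c1`, gives 9300 nM in a functional assay on Huh-7 cells (Homo sapiens) for inhibition, read by sulforhodamine B assay, with a stated time of 72 h; a lower number here means a stronger inhibitor, a higher number a weaker inhibitor.
Compound 2, `COc1ccc2cc(C(C)c3nnc4n3N=C(c3ccc(Cl)cc3Cl)CS4)ccc2c1`, gives 10700 nM in this assay.

Only these two compounds have been measured, and they share a common core; they differ only in the phenyl ring attached to the carbon with a double bond to nitrogen. Compound 2 carries the 2,4-dichlorophenyl group, and its number is the larger of the two, but the step of a 1.2-fold higher number from compound 1 to compound 2 (0.06 log units; within the scatter) lies within the scatter, so the two compounds cannot be told apart on these data.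

Compound 3, `COc1ccc2cc(C(C)c3nnc4n3N=C(c3ccc(F)cc3)CS4)ccc2c1`, has not yet been measured. It differs from compound 2 in one place: 4-fluorophenyl in place of 2,4-dichlorophenyl on a carbon with a double bond to nitrogen. Among the compounds with values here, the only measured step that bears on this change is the one from compound 1 to compound 2, a 1.2-fold higher number from compound 1 to compound 2 (0.06 log units; within the scatter), where exchanging one halogenated phenyl for another left the number essentially unchanged. The move to 4-fluorophenyl is a change of the same kind, so no step beyond the scatter is expected in this assay.

Compound 3 is therefore estimated at 12000 nM, with a likely range of 5000 nM to 30000 nM, which corresponds to an expected step of a 1.1-fold higher number from compound 2 to compound 3 (0.05 log units; within the scatter).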

Compound 3, half-maximal inhibitory concentration: 7000 nM
Beside the measured number, compound 3's estimate is 1.7-fold (0.23 log units) above it, within the range that was stated.
By their numbers in this assay, from the lowest: compounds 3, 1 and 2 (each within the scatter of the next).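

In this assay, putting 4-fluorophenyl in place of 2,4-dichlorophenyl on the carbon with a double bond to nitrogen gives a 1.5-fold lower number from compound 2 to compound 3 (0.18 log units; within the scatter), so this position tolerates the loss of both chlorine atoms and the arrival of a single fluorine without a change that can be told from the scatter. The second new comparison, fluoro in place of bromo on an aromatic carbon, gives a 1.3-fold lower number from compound 1 to compound 3 (0.12 log units; within the scatter), which extends the flat picture from the bromo and dichloro pair to a third halogen pattern, so all three halogenated phenyl groups shown here are indistinguishable in this test. None of the data shown offer an explanation for this flat picture.

On these data alone, all three compounds carry a halogenated phenyl at this position, so it remains open whether a ring bearing an amine or a carboxylic acid, or a plain unsubstituted phenyl, would move the number beyond the scatter. As far as these compounds go, it is also open whether any change elsewhere, such as replacing the methoxy group on the shared core with a longer chain, would do so.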